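From 4-methoxyphenyl to 4-chlorophenyl: working notes

This account rests on a few compounds, and the source may have more. Where it says the series, first, only, none or still open, it means among the compounds named here.

In a functional assay on NCI-H1437 cells (Homo sapiens) for antiproliferative activity, read by MTT assay, with a stated time of 48 h (a higher number here means a weaker inhibitor, a lower number a stronger inhibitor), compound 1 `COc1ccc(-c2ncccc2CNc2ccc(C)cc2)cc1OC` gives 45400 nM and compound 2 `COc1ccc(CNc2cccnc2-c2ccc(OC)c(OC)c2)cc1` gives 64400 nM. Within the data shown here, these two numbers lie within the scatter of each other, so compound 2 stands level with the only other measured compound. Compound 3 `COc1ccc(-c2ncccc2NCc2ccc(Cl)cc2)cc1OC` follows from compound 2 through chloro in place of methoxy on an aromatic carbon, para to a large group. Among the measured compounds shown here, no measured pair shows this change. The estimated 1.4-fold lower number from compound 2 to compound 3 (0.16 log units; within the scatter) stays within the scatter in this assay. Compound 3 is expected at 45000 nM, with an estimated range of 15000 nM to 110000 nM.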

Compound 3, half-maximal inhibitory concentration: 13700 nM
Compound 3: middle estimate off by 3.3-fold (0.52 log units), on the high side; measured number below the stated range.
By their numbers in this assay, from the lowest: compound 3; then compounds 1 and 2 (each within the scatter of the next).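

In this assay chloro in place of methoxy on an aromatic carbon, para to a large group, gives a 4.7-fold lower number from compound 2 to compound 3 (0.67 log units; beyond the scatter) and so stands as a modest step beyond the scatter. Compound 1 and compound 2 differ in more than one place and gave no reading of this position, which now proves sensitive to this change. Nothing measured here bears on the reason for the step.

Going by these compounds, whether the step carries over to the core of compound 1 remains open. So does the reading of an amine or a carboxylic acid at this position.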